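1,3-Benzothiazol-2-yl replaces 1,3-benzoxazol-2-yl in compound 2

This account rests on a few compounds, and the source may have more. Where it says the series, first, only, none or still open, it means among the compounds named here.

Compound 1 `Cc1ccc(-c2nnc(SCCCN3CCN(c4nc5ccccc5o4)CC3)o2)cc1` gives 154000 nM
Compound 2 `Fc1ccc(-c2nnc(SCCCN3CCN(c4nc5ccccc5o4)CC3)o2)cc1` gives 83800 nM
Compound 3 `Oc1ccc(-c2nnc(SCCCN3CCN(c4nc5ccccc5o4)CC3)o2)cc1` gives 502000 nM

All three numbers come from a functional assay on HepG2 cells (Homo sapiens) for inhibition, read by MTT assay, with a stated time of 72 h (a higher number here means a weaker inhibitor, a lower number a stronger inhibitor), and compound 2 stands at the low end of this small set. The gap to its nearest neighbour is a 1.8-fold lower number from compound 1 to compound 2 (0.26 log units; within the scatter) so those two cannot truly be told apart. The gap to the other compound is larger, namely a 6.0-fold higher number from compound 2 to compound 3 (0.78 log units; beyond the scatter) and that one is a real difference.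

Compound 4 `Fc1ccc(-c2nnc(SCCCN3CCN(c4nc5ccccc5s4)CC3)o2)cc1` differs from compound 2 in a single place, 1,3-benzothiazol-2-yl in place of 1,3-benzoxazol-2-yl on an amine nitrogen in a ring with 1,3-benzothiazol-2-yl in place of 1,3-benzoxazol-2-yl on an amine nitrogen in a ring. Going by the values given here, no measured step touches this place, since all three change a group on an aromatic carbon. Among the compounds with values here, those steps show only that a single swap can move the number modestly, so they give no direction here. The estimate therefore stays close to compound 2, with a wide range, and it means an expected 1.1-fold lower number from compound 2 to compound 4 (0.05 log units; within the scatter) in this assay with no shift beyond the scatter. Compound 4 is expected to give about 75000 nM with an estimated span from 28000 nM to 200000 nM as its range.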

Compound 4, half-maximal inhibitory concentration: 234000 nM
Compound 4: middle estimate off by 3.1-fold (0.49 log units), on the low side; the measured number lies above the stated range.
By their numbers in this assay, from the lowest: compounds 2, 1 and 4 (each within the scatter of the next, the first and the last beyond it); then compound 3.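

In this assay, going by these compounds alone, the earlier compounds changed only a group on an aromatic carbon, so this is the first look at the group on the amine nitrogen in a ring, and the swap gives a 2.8-fold higher number from compound 2 to compound 4 (0.45 log units; beyond the scatter), a shift towards a weaker inhibitor. Exchanging one oxygen for one sulfur, with the heavy-atom and hydrogen-bond counts unchanged, is therefore enough to move the number at this position. Nothing available explains this shift.

Going by these compounds, this is a single pair, with fluoro on the aromatic carbon, so it remains open whether the same swap would move the number similarly with methyl or hydroxy there. Also open, on these data alone, is what a 1H-benzimidazol-2-yl or a plain phenyl group would give on that amine nitrogen.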